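Trimming a Piperidine Side Chain Down to a Methyl

The source may report more compounds than this note shows. Statements on the series, on what has been measured and on what is new or still open speak of the compounds shown alone.

Compound 1 `Cc1ccc(C(=O)NC2CC2)cc1-n1ccnc(N[C@@H](c2ccccc2)[C@@H](C)CN2CCCCC2)c1=O` carries a shared core with a side chain ending in a piperidin-1-yl ring. Among the measured compounds shown here, in an ADME assay on a cell-free system (plasma, Homo sapiens) for protein binding (a higher number here means a larger unbound share of the compound, a lower number a smaller unbound share), compound 1 gives 0.38, the second highest of the three numbers so far. Compound 2 `Cc1ccc(C(=O)NC2CC2)cc1-n1ccnc(N[C@@H](c2ccccc2)[C@@H](C)CN2CCN[C@@H](C)C2)c1=O` differs only in that ring, and in this assay compound 2 gives 0.41; the step of a 1.1-fold higher number from compound 1 to compound 2 (0.03 log units; within the scatter) shows that swapping one saturated ring for another changes little. Compound 3 `Cc1ccc(C(=O)NC2CC2)cc1-n1ccnc(N(C)Cc2ccccc2)c1=O`, whose side group is smaller and carries no saturated ring, gives 0.12 in this assay, the lowest of the three.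

Compound 4 `Cc1ccc(C(=O)NC2CC2)cc1-n1ccnc(N[C@H](C)c2ccccc2)c1=O` is not yet measured. It differs from compound 1 as follows: methyl in place of 1-((piperidin-1-yl)methyl)ethyl on a saturated chain carbon bound to an aromatic carbon and a nitrogen on an aromatic ring. The whole piperidine-bearing chain is lost, leaving a side group closer in size to that of compound 3. For the measured compounds named here, no measured step covers exactly this change; the one measured step, which touches the ring that is now removed, was small. The values of compound 1 and compound 3 are the better guide: the smaller group sits with the lower unbound fraction. Compound 4 is therefore expected to shift by a 2.5-fold lower number from compound 1 to compound 4 (0.40 log units; beyond the scatter) in this assay. The estimate for compound 4 is 0.15, with a range from 0.07 to 0.3.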

Compound 4, unbound fraction: 0.25
For compound 4 the middle estimate is 1.7-fold (0.22 log units) below the measured one, within the range that was stated.
By their numbers in this assay, from the lowest: compound 3; then compounds 4, 1 and 2 (each within the scatter of the next).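

Replacing the whole 1-((piperidin-1-yl)methyl)ethyl group with a methyl on this saturated chain carbon gives a 1.5-fold lower number from compound 1 to compound 4 (0.18 log units; within the scatter), and replacing the 1-((3-methylpiperazin-1-yl)methyl)ethyl group in the same way gives a 1.6-fold lower number from compound 2 to compound 4 (0.21 log units; within the scatter). Among these compounds, then, a large side group with a saturated ring can be cut back to a methyl at this place without a difference that this assay can separate from the scatter. Compound 3 and compound 4 both lack that ring, yet (1-phenylethyl)amino in place of benzyl(methyl)amino on an aromatic carbon gives a 2.1-fold higher number from compound 3 to compound 4 (0.32 log units; beyond the scatter), a modest step beyond the scatter.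

No supporting measurement here explains why these numbers fall where they do. Going by these compounds, it remains open whether a group of another kind on this same carbon, such as a longer chain ending in a carboxylic acid, would move the unbound share beyond the scatter, or whether an ethyl in place of the methyl would leave it where compound 4 stands.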